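Adding a methoxy group to the far ring of compound 3

The compounds below may be only part of what the source reports. "The series", "measured", "known", "first", "only" and "open" are said of these compounds alone.

Compound 1 `Fc1ccccc1Nc1nc(-c2ccccn2)cs1` gives < 0.0167 h in an ADME assay on microsomes from liver (Mus musculus) for metabolic stability, read by LC-MS, using NADPH; a higher number here means that the compound lasts longer, a lower number that the compound disappears faster; this figure is a limit of the assay rather than a number (the limit of < 0.0167 h in this assay, at which 1 of the 3 values shown sits).
Compound 2 `COc1ccccc1Nc1nc(-c2ccccn2)cs1` gives 0.035 h in this assay.
Compound 3 `Fc1ccccc1Nc1nc(-c2ccccc2)cs1` gives 0.0483 h in this assay.

Of the two numbers measured, compound 3 has the highest, with compound 2 nearest, and the two lie within the usual scatter of each other. Compound 4 `COc1cccc(-c2csc(Nc3ccccc3F)n2)c1` differs from compound 3 by one change: methoxy in place of hydrogen on an aromatic carbon.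

Going by the values given here, two measured steps bear on this, though neither matches it. Placing a methoxy where a fluoro had been gave an at least 2.0-fold higher number from compound 1 to compound 2 (0.32 log units; beyond the scatter), and swapping pyridin-2-yl for phenyl gave an at least 2.8-fold higher number from compound 1 to compound 3 (0.46 log units; beyond the scatter). Among the compounds with values here, both raised the half-life, but both start from a limit, so their true size is uncertain, and no measured step adds a methoxy onto a hydrogen position of the phenyl ring. The expectation for compound 4 is therefore a step of about a 1.1-fold lower number from compound 3 to compound 4 (0.03 log units; within the scatter) in this assay, not beyond the scatter. Compound 4 is estimated at 0.045 h, with a likely range from 0.017 h to 0.12 h.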

Compound 4, half-life: 0.0633 h
For compound 4 the middle estimate is 1.4-fold (0.15 log units) below the measured one; measured number inside the range.
By their numbers in this assay, from the lowest: compounds 2, 3 and 4 (each within the scatter of the next). At a limit, below all of these: compound 1.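

In this assay, methoxy in place of hydrogen, meta to a large group on the phenyl ring, gives a 1.3-fold higher number from compound 3 to compound 4 (0.12 log units; within the scatter), so the half-lives of the two compounds cannot be told apart and this position takes the added group with no clear gain or loss. Unlike the two earlier steps, this one joins two real numbers, so its size can be read directly. Compound 1, the starting point of both earlier steps, stands at a limit of the assay rather than at a number: the limit of < 0.0167 h in this assay, at which 1 of the 4 values shown sits.

The compounds shown leave open whether a different group here, such as an amine, a carboxylic acid or a longer chain like ethoxy, would move the half-life beyond the scatter. They also leave open what methoxy would do elsewhere on this ring.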